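Halogen swap on the shared core: bromo to fluoro

A few compounds are considered here, and "the series" means these few. Any claim that something is new, unique, unknown or untested is made for them only; others in the source may bear on it.

Compound 1 `O=C(CSc1nnnn1-c1ccccc1)N/N=c1/scc(-c2ccc(Br)cc2)n1-c1ccccc1` gives 20.4% in a functional assay on C6 cells (Rattus norvegicus) for cytotoxicity, read by MTT assay, with a stated time of 24 h, tested at 200 ug/mL; on this read-out higher numbers stand for a weaker effect at the one concentration tested and lower numbers for a stronger effect. Among the compounds with values here, compound 2 `O=C(CSc1ncccn1)N/N=c1/scc(-c2ccc(Br)cc2)n1-c1ccccc1` gives 63.2% in this assay, which is the highest of the two numbers so far; the nearest is compound 1, and the step of a number 42.8 percentage points higher from compound 1 to compound 2 (beyond the scatter) lies beyond the scatter. Compound 3 `O=C(CSc1ncccn1)N/N=c1/scc(-c2ccc(F)cc2)n1-c1ccccc1` is not yet measured in this assay. It differs from compound 2 by fluoro in place of bromo on an aromatic carbon. Within the data shown here, no measured step concerns this place on the shared core: the only recorded step, a number 42.8 percentage points higher from compound 1 to compound 2 (beyond the scatter), exchanges the group on the sulfur and tells nothing about the halogen on the six-membered aromatic ring of carbon only. With nothing pointing either way, the expected step of a number 0.2 percentage points lower from compound 2 to compound 3 (within the scatter) is taken as none beyond the scatter, with a wide margin for the missing precedent. Compound 3 is therefore estimated at 63% in this assay, within 42% to 84%.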

Compound 3, a percentage reported as activity, at one concentration (the size of the read-out at that concentration, not a potency): 32.2%
Compound 3: middle estimate off by 30.8 percentage points, on the high side; measured number below the stated range.
By their numbers in this assay, from the lowest: compound 1; then compound 3; then compound 2.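

In this assay the halogen on the aromatic carbon proves to be a sensitive place: a number 31 percentage points lower from compound 2 to compound 3 (beyond the scatter), which means a stronger effect at the one concentration tested for 4-fluorophenyl than for 4-bromophenyl, with pyrimidin-2-yl held constant on the sulfur. The earlier step spoke only to the group on the sulfur, whereas this one shows that a large change also follows the exchange of one heavy atom for another, with no change in rings, hydrogen-bond donors, hydrogen-bond acceptors or net charge. Nothing available explains why the read-out moves with this exchange.

On these data alone, whether the same exchange gives a step of similar size with 1-phenyl-1H-tetrazol-5-yl on the sulfur remains open. The compounds shown also leave open how chloro, methoxy or an amine would read at this place.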